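The source may hold more compounds than are shown below. What is called first, only, known or untested is meant among the compounds shown, and "the series" means these compounds.

Going by the values given here, of the three compounds measured so far in an assay for inhibition of MAP kinase-interacting serine/threonine-protein kinase 1 (Homo sapiens), read by luminescence and ADP-Glo, with a stated time of 2 h (a higher number here means a weaker inhibitor, a lower number a stronger inhibitor), compound 2 `CC(=O)Nc1cccc(Cn2cc(-c3ccc4cn[nH]c4c3)ccc2=O)c1` gives 163 nM, the second highest of the three numbers. Its nearest neighbour is compound 1 `NC(=O)c1cccc(Cn2cc(-c3ccc4cn[nH]c4c3)ccc2=O)c1`, which gives 388 nM in this assay; compound 3 `Nc1n[nH]c2cc(-c3ccc(=O)n(Cc4cccc(Cl)c4)c3)ccc12` lies furthest away and gives 11 nM. Among the compounds with values here, the single one-place step measured here runs a 2.4-fold lower number from compound 1 to compound 2 (0.38 log units; beyond the scatter).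

Compound 4 `O=c1ccc(-c2ccc3cn[nH]c3c2)cn1Cc1cccc(C(F)(F)F)c1` differs from compound 2 in one place: trifluoromethyl in place of acetamido on an aromatic carbon. Within the data shown here, the only measured step that touches the same part of the molecule is the one from compound 1 to compound 2, a modest lowering, and it exchanged one group for another rather than for a trifluoromethyl, so it is a loose guide. Among the measured compounds shown here, compound 3 shows that much lower numbers are reachable, though no single step from compound 2 to compound 3 is given. On that basis a modest lowering in this assay is expected, roughly a 1.8-fold lower number from compound 2 to compound 4 (0.26 log units; within the scatter), with a clear chance of no change beyond the scatter. Compound 4 is therefore estimated to give 90 nM, within a range from 30 nM to 300 nM.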

Compound 4, half-maximal inhibitory concentration: 40 nM
Compound 4: middle estimate off by 2.3-fold (0.35 log units), on the high side; measured number inside the range.
By their numbers in this assay, from the lowest: compound 3; then compound 4; then compound 2; then compound 1.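

In this assay, trifluoromethyl gives the lowest number of the three groups tried at this position on the shared core, with a 4.1-fold lower number from compound 2 to compound 4 (0.61 log units; beyond the scatter) and a 9.7-fold lower number from compound 1 to compound 4 (0.99 log units; beyond the scatter). From highest number to lowest, the order at this carbon is therefore carbamoyl, acetamido, trifluoromethyl, and since trifluoromethyl has no hydrogen-bond donors or acceptors while acetamido has one of each, neither is needed here for a lower number. No measurement at hand gives the reason for this fall.

The compounds shown leave open whether other groups at this position, such as methyl, methoxy or nitrile, would match trifluoromethyl. They also leave open whether the same order would hold on the core of compound 3, which differs from compound 4 in more than one place.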